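A few compounds are considered here, and "the series" means these few. Any claim that something is new, unique, unknown or untested is made for them only; others in the source may bear on it.

Of the compounds shown here, three built around the same core have so far been tested in an assay on cells for inhibition of MAP kinase-interacting serine/threonine-protein kinase 1 (Homo sapiens), read by mobility shift assay, with stated times of 10 min and 60 min, in the presence of a further agent that is not named here; on this read-out lower numbers stand for stronger inhibition and higher numbers for weaker inhibition. Compound 1, `Cc1cc(-c2cccnc2)ccc1C(N)=O`, carries a methyl group on the amide-bearing ring and gives 22000 nM. Compound 2, `NC(=O)c1ccc(-c2ccc(N)nc2)cc1`, carries an amino group on the pyridine ring and gives 34000 nM. Compound 3, `NC(=O)c1ccc(-c2cncc(Cl)c2)cc1`, carries a chloro group on the pyridine ring; in this assay compound 3 gives 14200 nM. Its number differs from that of compound 1 only within the usual scatter of repeated measurements, so the two cannot be told apart, whereas compound 2 stands beyond the scatter with a higher number, meaning weaker inhibition.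

The next compound, compound 4, `NC(=O)c1ccc(-c2cccnc2)cc1`, differs from compound 3 in one place: hydrogen in place of chloro on an aromatic carbon. For the measured compounds named here, no pair of already measured compounds shows this change on its own, so there is no directly comparable step to lean on. Given how close compound 1 and compound 3 sit, the expectation is that removing the chloro group shifts the number only a little, if at all, and more likely toward weaker inhibition than stronger. The estimated step from compound 3 to compound 4 in this assay is a 1.5-fold higher number from compound 3 to compound 4 (0.19 log units; within the scatter). Compound 4 is therefore expected to give about 22000 nM, with a likely range from 9000 nM to 55000 nM.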

Compound 4, half-maximal inhibitory concentration: 8800 nM
Estimate against measurement, compound 4: 2.5-fold (0.40 log units) above; the whole stated range lies above it.
By their numbers in this assay, from the lowest: compounds 4, 3, 1 and 2 (each within the scatter of the next, the first and the last beyond it).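

In this assay, swapping chloro for hydrogen on the aromatic carbon two atoms from the ring nitrogen gives a 1.6-fold lower number from compound 3 to compound 4 (0.21 log units; within the scatter), so at this place the two substituents cannot be told apart and the chloro group brings no measurable gain in inhibition. For the compounds shown here, compound 4, which carries neither a substituent on this ring nor one on the amide-bearing ring, also provides a reference that the earlier compounds lacked: replacing the amino group with hydrogen gives a 3.9-fold lower number from compound 2 to compound 4 (0.59 log units; beyond the scatter) and replacing the methyl group with hydrogen gives a 2.5-fold lower number from compound 1 to compound 4 (0.40 log units; beyond the scatter), two modest steps showing that inhibition is weaker with either group than with hydrogen at its own place. Nothing shown here accounts for these differences.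

From the compounds shown here alone, only hydrogen and chloro are compared at this place, so it remains open whether a different group there, such as a methoxy group, a carboxylic acid or a longer chain, would shift the number beyond the scatter. Going by these compounds, it is also open whether the amino and methyl groups would weaken inhibition at this place as they do at their own, since each appears at only one place on the shared core.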